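The compounds below may be only part of what the source reports. "The series", "measured", "known", "first", "only" and "open" are said of these compounds alone.

Measured in a functional assay on HeLa cells (Homo sapiens) for antiproliferative activity, read by MTT assay, with a stated time of 72 h; on this read-out higher numbers stand for weaker inhibition and lower numbers for stronger inhibition:
Compound 1 `COc1cccc(N2C(=O)COc3ccc(-c4cnc(OC)c(NS(=O)(=O)c5ccc(F)cc5)c4)cc32)c1`: > 40000 nM (a limit)
Compound 2 `O=C1COc2ccc(-c3cnc(Cl)c(NS(=O)(=O)c4ccc(F)cc4)c3)cc2N1c1ccc(Cl)cc1`: > 40000 nM (a limit)

Compound 2 has no number in this assay, only the limit > 40000 nM. Among the measured compounds shown here, the same holds across the series so far, which stands at the limit of > 40000 nM in this assay, at which 2 of the 2 values shown sit.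

Compound 3 `COc1ncc(-c2ccc3c(c2)N(c2ccc(Cl)cc2)C(=O)CO3)cc1NS(=O)(=O)c1ccc(F)cc1` differs from compound 2 in one place, with methoxy in place of chloro on an aromatic carbon, next to the ring nitrogen (methoxy in place of chloro on an aromatic carbon).

Compound 1 also carries methoxy at that place, and its > 40000 nM is again a limit. For the measured compounds named here, no measured step gives a size for this change, so in this assay the expectation is no step beyond the scatter, in neither direction. The expected step is a number no higher from compound 2 to compound 3 (the limit leaves the size open). Compound 3 is estimated at about 40000 nM, with an expected range from 15000 nM to 60000 nM.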

Compound 3, half-maximal inhibitory concentration: 4830 nM
For compound 3 the middle estimate is 8.3-fold (0.92 log units) above the measured one; the measured number lies below the stated range.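

In this assay, among the compounds shown here, compound 3 is the first compound with a measured number, and methoxy in place of chloro on the aromatic carbon next to the ring nitrogen gives an at least 8.2-fold lower number from compound 2 to compound 3 (0.91 log units; beyond the scatter). Methoxy at that place does not bring a number on its own, as compound 1 also carries it: 4-chlorophenyl in place of 3-methoxyphenyl on the amide-type nitrogen in a ring gives an at least 8.2-fold lower number from compound 1 to compound 3 (0.91 log units; beyond the scatter), so among these compounds only the pairing of the two groups in compound 3 gets under the limit. Both steps are lower bounds only, because the other two compounds stand at a limit: the limit of > 40000 nM in this assay, at which 2 of the 3 values shown sit.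

As far as these compounds go, the true size of each step remains open. So does whether an amine, an ethoxy group or a hydroxyl on that same carbon would match methoxy in this assay.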